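Compound 3 and the carbamoyl question

The source may hold more compounds than are shown below. What is called first, only, known or untested is meant among the compounds shown, and "the series" means these compounds.

compound 1 `COc1ccc(S(=O)(=O)Nc2cccc3cc[nH]c23)cc1`: 1.1 ug/mL
compound 2 `N#Cc1c[nH]c2c(NS(=O)(=O)c3ccc(C(N)=O)cc3)cccc12`: 2.5 ug/mL
compound 3 `COc1ccc(S(=O)(=O)Nc2cccc3c(Cl)c[nH]c23)cc1`: 0.76 ug/mL

In a functional assay on P388 cells (Mus musculus) for antiproliferative activity (a lower number here means a stronger inhibitor, a higher number a weaker inhibitor), compound 1 and compound 3 lie within the scatter of each other, while compound 2 stands at a higher number than compound 3, beyond the scatter. Compound 4 `NC(=O)c1ccc(S(=O)(=O)Nc2cccc3c(Cl)c[nH]c23)cc1` has carbamoyl in place of methoxy on an aromatic carbon. For the measured compounds named here, the only measured step, a 1.4-fold lower number from compound 1 to compound 3 (0.16 log units; within the scatter), concerns chloro and does not cover this change. The nearest evidence is compound 2 at 2.5 ug/mL, which carries carbamoyl but has nitrile instead of chloro. The expected step is a 2.0-fold higher number from compound 3 to compound 4 (0.30 log units; within the scatter), towards a higher number. The estimate for compound 4 is 1.5 ug/mL, with an expected range of 0.5 ug/mL to 4 ug/mL.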

Compound 4, half-maximal inhibitory concentration: 0.87 ug/mL
For compound 4 the middle estimate is 1.7-fold (0.24 log units) above the measured one, and the stated range covers the measured number.
By their numbers in this assay, from the lowest: compounds 3, 4 and 1 (each within the scatter of the next); then compound 2.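

In this assay, carbamoyl in place of methoxy, on an aromatic carbon para to a large group, gives a 1.1-fold higher number from compound 3 to compound 4 (0.06 log units; within the scatter) and so leaves the number within the scatter. With carbamoyl present in both compounds, chloro in place of cyano gives a 2.9-fold lower number from compound 2 to compound 4 (0.46 log units; beyond the scatter) and lies beyond the scatter, so the higher number of compound 2 goes with its nitrile and not with its carbamoyl. No evidence on why either step has this size is available.

Going by these compounds, whether a carboxylic acid or an amine at this position would also stay within the scatter of compound 3 remains open. So does whether chloro and carbamoyl act independently, since the carbamoyl compound with hydrogen in place of chloro is not among those shown.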